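Ester shortening in orexin type 2 antagonists

This account rests on a few compounds, and the source may have more. Where it says the series, first, only, none or still open, it means among the compounds named here.

Measured so far:
compound 1 `CC(C)OC(=O)c1ccccc1C(=O)N1C[C@H](Oc2cc(C#N)ccn2)CC[C@H]1C` — 38 nM
compound 2 `CCc1ccnc(O[C@@H]2CC[C@@H](C)N(C(=O)c3ccccc3-n3nccn3)C2)c1` — 11 nM
compound 3 `C[C@@H]1CC[C@@H](Oc2ccccn2)CN1C(=O)c1ccccc1-n1nccn1` — "not determined" (no result reported)

The series shares a piperidine-amide core carrying an aryloxy substituent, varied at the amide-bearing aromatic ring and at the pyridine. In a functional assay on CHO-K1 cells for antagonist activity at Orexin receptor type 2 (Homo sapiens), read by FLIPR and calcium flux (a higher number here means a weaker inhibitor, a lower number a stronger inhibitor), compound 1 gives 38 nM, the highest of the two numbers available. Its nearest neighbour is compound 2, which gives 11 nM in this assay, a gap that lies beyond the usual scatter. Compound 3 carries the same triazolyl-bearing amide as compound 2 on an unsubstituted pyridine, but in this assay compound 3 gives "not determined" (no result reported), so no comparison can be drawn.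

The unmeasured compound 4 `CCOC(=O)c1ccccc1C(=O)N1C[C@H](Oc2cc(C#N)ccn2)CC[C@H]1C` differs from compound 1 in one place: hydrogen in place of methyl on a saturated chain carbon bound to an oxygen next to a carbonyl group and a saturated chain carbon. Going by the values given here, no comparable step between measured compounds exists, so the expectation rests on the small size of the change alone. Compound 4 is expected to remain close to compound 1, with a step of a 1.1-fold lower number from compound 1 to compound 4 (0.04 log units; within the scatter) that stays within the scatter and points to no clear direction. On that basis compound 4 is estimated to give 35 nM in this assay, with a likely range from 15 nM to 80 nM.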

Compound 4, half-maximal inhibitory concentration in the Orexin receptor type 2 assay: 21 nM
Estimate against measurement, compound 4: 1.7-fold (0.22 log units) above; the range from low to high includes it.
By their numbers in the Orexin receptor type 2 assay, from the lowest: compounds 2, 4 and 1 (each within the scatter of the next, the first and the last beyond it).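

Cutting isopropoxycarbonyl back to ethoxycarbonyl provides the first measured step at this position: in the Orexin receptor type 2 assay the exchange of methyl for hydrogen amounts to a 1.8-fold lower number from compound 1 to compound 4 (0.26 log units; within the scatter) and thus cannot be told apart from repeat-measurement noise, so this methyl is not needed to hold the activity seen with compound 1. The same change also leaves the second measured property without a clear shift, since in a physicochemical assay for solubility, at pH 7 (a higher number here means a more soluble compound, a lower number a less soluble compound), compound 1 gives 115000 nM and compound 4 gives 121000 nM with a 1.1-fold higher number from compound 1 to compound 4 (0.02 log units; within the scatter) as the step between them. Nothing measured here accounts for either result.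

The compounds shown leave open how far this ester tolerates change, since a methoxycarbonyl group, a longer chain such as butoxycarbonyl, or a carboxylic acid at the same place could each behave differently from the isopropoxycarbonyl and ethoxycarbonyl groups. They also leave open whether the change from isopropoxy to ethoxy would read the same way with an ethyl group on the pyridine in place of the nitrile.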